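A few compounds are considered here, and "the series" means these few. Any claim that something is new, unique, unknown or untested is made for them only; others in the source may bear on it.

Working notes on the series. a functional assay on ECa-109 cells (Homo sapiens) for inhibition, read by MTT assay, with a stated time of 72 h (on this read-out lower numbers stand for stronger inhibition and higher numbers for weaker inhibition), is the read-out throughout. Compound 1 is `CC(C)c1ccc(-c2nc(SCc3cn(CC(=O)NC(=O)Nc4ccccn4)nn3)nc(Nc3ccc(F)cc3)c2C#N)cc1`; in this assay compound 1 gives > 64000 nM, which is a limit of the assay and not a number, so compound 1 stands only at the limit of > 64000 nM in this assay, at which 1 of the 2 values shown sits, and no exact position among the shown values can be given for it. Compound 2 is `CC(C)c1ccc(-c2nc(SCc3cn(CC(=O)NC(=O)Nc4ccccn4)nn3)nc(Nc3cccc(C(F)(F)F)c3)c2C#N)cc1`; in this assay compound 2 gives 24200 nM. Among the compounds with values here, the one measured step, an at least 2.6-fold lower number from compound 1 to compound 2 (0.42 log units; beyond the scatter), shows a change at the same position moving the number off the limit.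

Compound 3 is `CC(C)c1ccc(-c2nc(SCc3cn(CC(=O)NC(=O)Nc4ccccn4)nn3)nc(Nc3ccccc3F)c2C#N)cc1`. Its change from compound 1 is 2-fluorophenyl in place of 4-fluorophenyl on a nitrogen on an aromatic ring. The measured step from compound 1 to compound 2 is the only one touching this position, and it concerns a different group, so it bears on the present step only loosely. The fluorine is kept and only moved within the ring, so little movement beyond the scatter is expected; a modest drop of the number, an at least 1.2-fold lower number from compound 1 to compound 3 (0.10 log units; that floor lies within the scatter), is the most that is expected, with a fair chance that compound 3 again reads only as a limit. Compound 3 is estimated at 50000 nM, within 15000 nM to 200000 nM.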

Compound 3, half-maximal inhibitory concentration: 15500 nM
For compound 3 the middle estimate is 3.2-fold (0.51 log units) above the measured one; low and high end bracket the measured number.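

In this assay, moving the fluorine within the ring, with the same atoms joined differently, gives an at least 4.1-fold lower number from compound 1 to compound 3 (0.61 log units; beyond the scatter), so at this position the place of the fluorine counts and not only its presence. Compound 1 stands only at a limit of the assay, which makes the size of that step a floor: the limit of > 64000 nM in this assay, at which 1 of the 3 values shown sits. The comparison with the trifluoromethyl analogue gives a 1.6-fold lower number from compound 2 to compound 3 (0.19 log units; within the scatter), which lies within the scatter, so compound 2 and compound 3 cannot be put in order, and a 3-(trifluoromethyl)phenyl group is not required for a number off the limit.

The compounds shown leave open how a plain phenyl, with no substituent on the ring, would read on the same nitrogen, and so whether the 2-fluorophenyl group improves on it or the 4-fluorophenyl group falls short of it. Also open, going by these compounds, is whether the fluorine is specifically needed, or whether a chlorophenyl or methoxyphenyl group at this position would read the same in this assay.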